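Trifluoromethyl in place of chloro on the benzyl ring

This account rests on a few compounds, and the source may have more. Where it says the series, first, only, none or still open, it means among the compounds named here.

Compound 1, `O=C(NCc1cn(Cc2ccc(F)cc2)nn1)c1cn(-c2ccccc2)nc1-c1ccc(F)cc1`, in a functional assay on HeLa cells (Homo sapiens) for antiproliferative activity, read by sulforhodamine B assay, with a stated time of 48 h; a lower number here means a stronger inhibitor of growth, a higher number a weaker inhibitor of growth: 1200 nM
Compound 2, `O=C(NCc1cn(Cc2ccc(Cl)cc2)nn1)c1cn(-c2ccccc2)nc1-c1ccc(F)cc1`, in this assay: 210 nM

Compound 2 stands lowest of the two numbers, with compound 1 above it: a 5.7-fold lower number from compound 1 to compound 2 (0.76 log units; beyond the scatter). Compound 3, `O=C(NCc1cn(Cc2ccc(C(F)(F)F)cc2)nn1)c1cn(-c2ccccc2)nc1-c1ccc(F)cc1`, differs from compound 2 by trifluoromethyl in place of chloro on an aromatic carbon. For the measured compounds named here, only the step from compound 1 to compound 2 bears on this change, and it was modest; a further change at the same place is therefore expected to move the number little, perhaps slightly lower. For compound 3 the expected step is a 1.4-fold lower number from compound 2 to compound 3 (0.15 log units; within the scatter), giving an estimate of 150 nM with a range from 50 nM to 500 nM.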

Compound 3, concentration for 50% growth inhibition: 250 nM
Estimate against measurement, compound 3: 1.7-fold (0.22 log units) below, and the stated range covers the measured number.
By their numbers in this assay, from the lowest: compounds 2 and 3 (each within the scatter of the next); then compound 1.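

In this assay, the step of a 1.2-fold higher number from compound 2 to compound 3 (0.08 log units; within the scatter) lies within the scatter, so this position does not separate chloro, with 1 heavy atom, from trifluoromethyl, with 4. The lower number seen with chloro is therefore not unique to it, as the other step, a 4.8-fold lower number from compound 1 to compound 3 (0.68 log units; beyond the scatter), lies beyond the scatter and shows that trifluoromethyl also parts from fluoro. No measurement here explains why fluoro differs from the other two groups. The compounds shown leave open how an amine, a carboxylic acid or a longer chain would behave at this position.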